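The source may report more compounds than this note shows. Statements on the series, on what has been measured and on what is new or still open speak of the compounds shown alone.

Measured so far in a functional assay on RS4-11 cells (Homo sapiens) for inhibition, read by CCK-8 assay, with a stated time of 48 h, tested at 20 uM; a higher number here means more inhibition of growth at the concentration tested, a lower number less inhibition of growth:

- Compound 1 `Cc1ccc(S(=O)(=O)Oc2ccccc2/C=C(\C#N)C(=O)Nc2nnc(C)s2)cc1`: 33%
- Compound 2 `COc1ccc(Cc2nnc(NC(=O)/C(C#N)=C/c3ccccc3OS(=O)(=O)c3ccc(C)cc3)s2)cc1`: 70%
- Compound 3 `Cc1ccc(S(=O)(=O)Oc2ccccc2/C=C(\C#N)C(=O)Nc2nnc(Cc3cccc4ccccc34)s2)cc1`: 73%

These three compounds share one core and differ only in what sits on a saturated chain carbon bound to an aromatic carbon. Compound 3, at 73%, stands well clear of compound 1, with a number 40 percentage points higher from compound 1 to compound 3 (beyond the scatter). Compound 2 shows a similar gain, with a number 37 percentage points higher from compound 1 to compound 2 (beyond the scatter). No real separation exists between the two better compounds, with a number 3 percentage points higher from compound 2 to compound 3 (within the scatter).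

Compound 4 `N#C/C(=C\c1ccccc1OS(=O)(=O)c1ccc(Cl)cc1)C(=O)Nc1nnc(Cc2cccc3ccccc23)s1` keeps everything in compound 3 except one group: chloro in place of methyl on an aromatic carbon. This places chloro in place of methyl on an aromatic carbon, turning 4-methylphenyl into 4-chlorophenyl. For the measured compounds named here, no measured step touches this place, so none gives a direct size for the change. The two large steps replaced a hydrogen with a whole aromatic group, which is a much bigger alteration, while the swap behind a number 3 percentage points higher from compound 2 to compound 3 (within the scatter) stayed within the scatter. In this assay, on these data alone, no shift beyond the scatter is therefore expected in either direction, though this remains untested. The estimated step is a number 1 percentage points lower from compound 3 to compound 4 (within the scatter). For compound 4, the estimated value is 72%, with an expected range of 58% to 85%.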

Compound 4, percent growth inhibition at one concentration: 68%
Beside the measured number, compound 4's estimate is 4 percentage points above it; the range from low to high includes it.
By their numbers in this assay, from the lowest: compound 1; then compounds 4, 2 and 3 (each within the scatter of the next).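

For the compounds shown here, this is the first reading on the (4-methylphenyl)sulfonyl part of the molecule, as every earlier step concerned the group on the saturated chain carbon. In this assay, going from 4-methylphenyl to 4-chlorophenyl gives a number 5 percentage points lower from compound 3 to compound 4 (within the scatter), so with the naphthalen-1-yl group held constant, exchanging one heavy atom for another on this aromatic carbon leaves growth inhibition at the tested concentration indistinguishable within the usual scatter. Nothing available here explains why these two groups read alike.

The compounds shown leave open whether this position would also accept something quite different from methyl or chloro, such as an amine, a carboxylic acid or a longer chain. They also leave open whether the same exchange of chloro for methyl would read alike in compound 1 or compound 2, where the group on the saturated chain carbon differs, and how compound 3 and compound 4 would compare across a full range of concentrations rather than at a single one.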